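Demethylating the Aryl Ether in a Sulfonamide Series

This account rests on a few compounds, and the source may have more. Where it says the series, first, only, none or still open, it means among the compounds named here.

Compound 2 `COc1ccc(S(=O)(=O)NCCCNc2nccc(-c3[nH]c(-c4ccccc4)nc3-c3ccc(Cl)c(OC)c3)n2)cc1` gives 1800 nM in a functional assay on LOX IMVI cells (Homo sapiens) for cytotoxicity, read by MTT assay, with a stated time of 24 h; on this read-out lower numbers stand for stronger inhibition and higher numbers for weaker inhibition. Among the two compounds measured it carries the highest number, and its nearest neighbour is compound 1 `COc1cc(-c2nc(-c3ccccc3)[nH]c2-c2ccnc(NCCCNS(=O)(=O)c3ccc(C(F)(F)F)cc3)n2)ccc1Cl`, which gives 1780 nM; the two lie within the scatter. Among the compounds with values here, the only measured step is a 1.0-fold higher number from compound 1 to compound 2 (0.00 log units; within the scatter), and it concerns a different change, methoxy in place of trifluoromethyl, not the oxygen altered here. Compound 3 `COc1ccc(S(=O)(=O)NCCCNc2nccc(-c3[nH]c(-c4ccccc4)nc3-c3ccc(Cl)c(O)c3)n2)cc1` differs from compound 2 by hydrogen in place of methyl on an oxygen on an aromatic ring. Within the data shown here, no measured step touches this oxygen, so there is no direct guidance, and the one step available was flat. In the absence of evidence for a shift, the step of no change at the digits printed from compound 2 to compound 3 (within the scatter) is expected to lie within the scatter. Compound 3 is therefore estimated at 1800 nM in this assay, with a range from 700 nM to 4500 nM.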

Compound 3, half-maximal inhibitory concentration: 36800 nM
The estimate for compound 3 lay 20-fold (1.31 log units) below the measured number; the whole stated range lies below it.
By their numbers in this assay, from the lowest: compounds 1 and 2 (each within the scatter of the next); then compound 3.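

In this assay, the oxygen on the 4-chloro-3-methoxyphenyl group proves sensitive: replacing methoxy with hydroxy gives a 20-fold higher number from compound 2 to compound 3 (1.31 log units; beyond the scatter), and the step is large. Within the data shown here, the only earlier step, methoxy in place of trifluoromethyl, lay within the scatter and concerned a different place, so it gave no sign that a single methyl on this oxygen could matter so much. Nothing at hand bears on why the number rises at this position.

The compounds shown leave open whether this methyl is specifically required or whether another group on the oxygen, such as ethyl, would hold the number near that of compound 2. They also leave open whether an amine at this place would behave like the hydroxy, and whether the same step would recur with the trifluoromethyl group of compound 1.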